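The source may hold more compounds than are shown below. What is called first, only, known or untested is meant among the compounds shown, and "the series" means these compounds.

Measured compounds, with their values:

Compound 1, `COC(=O)c1cc2c(Nc3ccc(OC(F)(F)F)cc3)ncnc2s1`, gives > 10000 nM in an ADME assay on BaF3 cells (Mus musculus) for cytotoxicity; a lower number here means that less compound is needed, a higher number that more compound is needed for the effect; this value is a limit of the assay.
Compound 2, `FC(F)(F)Oc1ccc(Nc2ncnc3nn(Cc4cccnc4)cc23)cc1`, gives > 10000 nM in this assay; again a limit.
Compound 3, `CCn1ncc2c(Nc3ccc(OC(F)(F)F)cc3)ncnc21`, gives > 10000 nM in this assay; again a limit.

Compound 3 therefore stands at the limit, and so does every other compound shown: the limit of > 10000 nM in this assay, at which 3 of the 3 values shown sit. Within the data shown here, no compound returns a number, and no pair of measured compounds differs in one place, so no step size can be read from the series itself. Compound 4, `FC(F)(F)Oc1ccc(Nc2ncnc3c2cnn3Cc2ccccc2)cc1`, differs from compound 3 as phenyl in place of methyl on a saturated chain carbon bound to an aromatic nitrogen.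

With only limits to go on, the expectation for compound 4 is simply that it behaves as the rest of the series does: the step that the limit leaves unreadable from compound 3 to compound 4 is expected to be none beyond the scatter. Compound 4 is accordingly estimated at 15000 nM, with a range from 5000 nM to 50000 nM, and the most likely outcome is that this assay again reports only a limit for compound 4 rather than a number.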

Compound 4, half-maximal effective concentration: > 10000 nM
Compound 4: a limit, no number; the forecaster's own chance of this, stated with the estimate: 85%; the middle value lies beyond the limit too.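

No step can be read from compound 3 to compound 4, since both values in this assay are limits and not numbers: the limit of > 10000 nM in this assay, at which 4 of the 4 values shown sit.

The compounds shown leave open how far each lies beyond that limit, and whether any change on the shared core would return a number in this assay.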